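The source may report more compounds than this note shows. Statements on the series, on what has been measured and on what is new or still open speak of the compounds shown alone.

Measured so far in an assay on isolated protein for inhibition of protein deacetylase HDAC6 (Homo sapiens); on this read-out lower numbers stand for stronger inhibition and higher numbers for weaker inhibition:
- compound 1 `Cc1ccc(-c2noc(-c3ccc(C(=O)C(F)(F)F)s3)n2)cc1` gives 860 nM
- compound 2 `O=C(c1ccc(-c2ncc(-c3ccccc3)s2)s1)C(F)(F)F` gives 1350 nM
- compound 3 `O=C(c1ccc(-c2nc(-c3cccnc3)no2)s1)C(F)(F)F` gives 840 nM

Compound 3 has the lowest of the three numbers, but its gaps to compound 1 and to compound 2 both lie within the scatter, so no order among them can be claimed. Compound 4 `O=C(c1ccc(-c2nc(-c3cccs3)no2)s1)C(F)(F)F` differs from compound 3 by thiophen-2-yl in place of pyridin-3-yl on an aromatic carbon. Within the data shown here, the only measured step that touches this ring is a 1.0-fold lower number from compound 1 to compound 3 (0.01 log units; within the scatter), where swapping one aromatic ring for another at this position left the number unchanged. On that basis, the step of a 1.1-fold higher number from compound 3 to compound 4 (0.03 log units; within the scatter) is expected to stay within the scatter. Compound 4 is therefore estimated at 900 nM, with a likely range from 400 nM to 2000 nM in this assay.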

Compound 4, half-maximal inhibitory concentration: 670 nM
For compound 4 the middle estimate is 1.3-fold (0.13 log units) above the measured one, within the range that was stated.
By their numbers in this assay, from the lowest: compounds 4, 3, 1 and 2 (each within the scatter of the next).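

Among these compounds, at this position on the ring with 2 nitrogen and 1 oxygen, a five-membered aromatic ring with sulfur now stands where the earlier compounds carried six-membered rings. this assay gives a 1.3-fold lower number from compound 3 to compound 4 (0.10 log units; within the scatter) and a 1.3-fold lower number from compound 1 to compound 4 (0.11 log units; within the scatter) for this swap. All three aromatic rings therefore fit here with no readable difference, and no measurement available explains this.

Still open, as far as these compounds go, is whether the number stays in this range only with an aromatic ring, or also with a non-aromatic group such as an amine or a carboxylic acid at this position.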